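Swapping the acrylamide end for a dimethyl-substituted enamide

The source may hold more compounds than are shown below. What is called first, only, known or untested is meant among the compounds shown, and "the series" means these compounds.

Measured compounds:
- compound 1 `COc1ccc(Nc2nc(Oc3cccc(NC(=O)C=C(C)C)c3)c3sccc3n2)cc1`: 18100 nM
- compound 2 `C=CC(=O)Nc1cccc(Oc2nc(Nc3cccc(C#N)c3)nc3ccsc23)c1`: 4340 nM

In a functional assay on A549 cells (Homo sapiens) for inhibition, read by MTT assay, with a stated time of 72 h (on this read-out lower numbers stand for stronger inhibition and higher numbers for weaker inhibition), compound 2 gives the lowest of the two numbers; compound 1 sits at a higher value, beyond the scatter. Compound 3 `CC(C)=CC(=O)Nc1cccc(Oc2nc(Nc3cccc(C#N)c3)nc3ccsc23)c1` is compound 2 with 2-methylprop-1-en-1-yl in place of vinyl on a carbonyl carbon. Going by the values given here, no step between measured compounds isolates this change, and compound 1 differs from compound 3 in a second place, so it is only a hint. A step toward weaker inhibition is expected in this assay, a 3.5-fold higher number from compound 2 to compound 3 (0.54 log units; beyond the scatter). Compound 3 is therefore estimated at 15000 nM, with a range of 5000 nM to 50000 nM.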

Compound 3, half-maximal inhibitory concentration: 16900 nM
The estimate for compound 3 lay 1.1-fold (0.05 log units) below the measured number; the measured number falls inside the stated range.
By their numbers in this assay, from the lowest: compound 2; then compounds 3 and 1 (each within the scatter of the next).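

Within this assay, 2-methylprop-1-en-1-yl in place of vinyl on the carbonyl carbon, with everything else unchanged, weakens inhibition beyond the scatter (a 3.9-fold higher number from compound 2 to compound 3 (0.59 log units; beyond the scatter)). With the 2-methylprop-1-en-1-yl end held fixed, 3-cyanophenyl in place of 4-methoxyphenyl on the nitrogen stays within the scatter (a 1.1-fold lower number from compound 1 to compound 3 (0.03 log units; within the scatter)). Nothing available explains either result. On these data alone, whether 4-methoxyphenyl would also match 3-cyanophenyl with the vinyl end remains open. So does how this carbonyl position would respond to a chain ending in an amine.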